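The compounds below may be only part of what the source reports. "The series", "measured", "known", "first", "only" and "open" are said of these compounds alone.

Measured so far:
compound 1, `CN(C)c1ncnc2c1ncn2Cc1ccc(Cl)cc1`, 0%
compound 2, `CN(C)c1ncnc2c1ncn2C`, 30%

In a functional assay on the whole organism for inhibition, with Rattus norvegicus as the target, at a dose of 25 mg/kg by the intraperitoneal route (a higher number here means more inhibition at the dose given (going by the name of the read-out), a lower number less inhibition), compound 2 gives the higher of the two numbers, with compound 1 standing lower by a gap beyond the scatter. Compound 3, `CN(C)c1ncnc2c1ncn2C1CCCCC1`, has not been measured. It differs from compound 2 by one change, (cyclohexyl in place of methyl on an aromatic nitrogen). Compound 1 shows that a larger group on that nitrogen went with a lower number, so a downward step is expected, estimated at a number 15 percentage points lower from compound 2 to compound 3 (beyond the scatter), close to the edge of the scatter. Compound 3 is therefore expected to give 15%, within a range from 0% to 40%.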

Compound 3, a percentage reported as inhibition, in the whole organism at one dose (the size of the read-out at that dose, not a potency): 70%
Compound 3: middle estimate off by 55 percentage points, on the low side, outside the stated range (above it).
By their numbers in this assay, from the lowest: compound 1; then compound 2; then compound 3.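

Cyclohexyl in place of methyl on the aromatic nitrogen gives a number 40 percentage points higher from compound 2 to compound 3 (beyond the scatter) in this assay, so a larger group at this position does not always go with a lower number. The group on compound 1 is also larger than methyl, yet compound 1 gives 0%, so the kind of group matters here and not only its size. No measurement available here explains the rise.

On these data alone, whether a smaller ring such as cyclopentyl or an open chain such as n-butyl would match cyclohexyl stays open. So does the effect of an amine or a hydroxyl group on the cyclohexyl ring.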